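Swapping the Aryl Group on Two Cores

The compounds below may be only part of what the source reports. "The series", "measured", "known", "first", "only" and "open" are said of these compounds alone.

Compound 1 `O=c1oc(-c2ccccc2)nn1CCCCN1CCN(c2ccc(F)cc2)CC1` and compound 2 `O=c1oc(-c2ccccc2)nn1CCCCN1CCN(c2ccccn2)CC1` share one core, while compound 3 `O=C1CCc2ccccc2N1CCCCN1CCN(c2ccc(F)cc2)CC1` and compound 4 `O=C1CCc2ccccc2N1CCCCN1CCN(c2ccccn2)CC1` share another; the difference between the two cores is not broken down here. In an assay on membranes from liver for displacement of a labelled ligand from Sigma intracellular receptor 2 (Rattus norvegicus), read by scintillation counting, with a stated time of 120 min, in the presence of a further agent that is not named here (on this read-out lower numbers stand for stronger inhibition and higher numbers for weaker inhibition), compound 1 gives 686 nM, and compound 2 gives 2800 nM. The change between them is pyridin-2-yl in place of 4-fluorophenyl on an amine nitrogen in a ring, and it produces a 4.1-fold higher number from compound 1 to compound 2 (0.61 log units; beyond the scatter). Compound 3 gives 21 nM in this assay, the lowest number of the three measured values. Compound 4 carries the same change on the second core, (pyridin-2-yl in place of 4-fluorophenyl on an amine nitrogen in a ring), and has not yet been measured in this assay. Going by the values given here, because a 4.1-fold higher number from compound 1 to compound 2 (0.61 log units; beyond the scatter) is the only precedent and is modest, a weakening of similar size is expected for compound 4, a 4.0-fold higher number from compound 3 to compound 4 (0.61 log units; beyond the scatter). That expectation rests on a single pair, compound 1 and compound 2, so whether the change behaves the same way on the core of compound 3 is uncertain, and the range is drawn widely. Compound 4 is accordingly expected to give 85 nM in this assay, with a range from 30 nM to 250 nM.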

Compound 4, inhibition constant: 73 nM
Compound 4: middle estimate off by 1.2-fold (0.07 log units), on the high side; measured number inside the range.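

In this assay, the same exchange of groups, now made on the second core, gives a 3.5-fold higher number from compound 3 to compound 4 (0.54 log units; beyond the scatter). Set beside the earlier step, the change carries over from one core to the other in both direction and size: the same change on two cores in this assay, a 4.1-fold higher number (0.61 log units; beyond the scatter) from compound 1 to compound 2 and a 3.5-fold higher number (0.54 log units; beyond the scatter) from compound 3 to compound 4, 1.2-fold (0.07 log units) apart, within the scatter of two such steps. Going by these compounds alone, this agreement covers only two cores and one exchange of groups, so it does not show that the step would keep its size on a third core, and it does not explain why the step has this size.

The compounds shown leave open whether a similar step would follow with a pyrimidin-2-yl or an unsubstituted phenyl group in the same place. They also leave open whether the two cores would continue to track each other with a longer chain leading to the ring with two nitrogens.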